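Thiophen-3-yl to pyridin-3-yl: working notes on the series

This account rests on a few compounds, and the source may have more. Where it says the series, first, only, none or still open, it means among the compounds named here.

In a functional assay on MDA-MB-231 cells (Homo sapiens) for cytotoxicity, read by ELISA, with a stated time of 2 days (a higher number here means a weaker inhibitor, a lower number a stronger inhibitor), the measured compounds are these:
- compound 1 `Oc1cccc(-c2cc(-c3ccccc3)cc(-c3cccs3)n2)c1` gives 18100 nM
- compound 2 `Oc1cccc(-c2cc(-c3ccccc3)nc(-c3ccsc3)c2)c1` gives 19000 nM

Compound 2 stands at 19000 nM and compound 1 at 18100 nM in the same read-out. These two values lie within the scatter of each other, and neither compound ranks ahead of the other.

The next structure is compound 3 `Oc1cccc(-c2cc(-c3ccccc3)nc(-c3cccnc3)c2)c1`, which carries pyridin-3-yl in place of thiophen-3-yl on an aromatic carbon and is otherwise identical to compound 2. The exchanged group sits next to the ring nitrogen of a six-membered aromatic ring with 1 nitrogen.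

Among the compounds with values here, no pair of measured compounds differing in one place is available, and the data therefore hold no direct measure of such a change. In this assay no step beyond the scatter is expected, in either direction. The reference for this expectation is compound 2 at 19000 nM as the measured neighbour. The estimated change is a 1.2-fold lower number from compound 2 to compound 3 (0.07 log units; within the scatter) and remains an expectation only. For compound 3 the estimated value is 16000 nM with an expected range from 6000 nM to 40000 nM in this measurement.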

Compound 3, half-maximal inhibitory concentration: 22800 nM
Estimate against measurement, compound 3: 1.4-fold (0.15 log units) below; the range from low to high includes it.
By their numbers in this assay, from the lowest: compounds 1, 2 and 3 (each within the scatter of the next).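

Within the data shown here, this is the first direct reading of a one-place change at this position. In this assay, pyridin-3-yl in place of thiophen-3-yl on an aromatic carbon, next to the ring nitrogen, gives a 1.2-fold higher number from compound 2 to compound 3 (0.08 log units; within the scatter), so this read-out does not separate the five-membered aromatic ring with its sulfur from the six-membered aromatic ring with its nitrogen at this place. No measured information accompanies this step that could explain the result or assign it to any property of either group.

The compounds shown leave open whether any group at this position can carry this assay beyond the scatter, for instance an amine, a carboxylic acid or a longer alkyl chain in place of the aromatic ring. They also leave open whether the same exchange would read alike with a different group in place of the 3-hydroxyphenyl group or the phenyl group, as both stay fixed across this single step.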